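A few compounds are considered here, and "the series" means these few. Any claim that something is new, unique, unknown or untested is made for them only; others in the source may bear on it.

Compound 1 `Cc1ccccc1CNc1ncnn1-c1cccc(Cl)c1Cl`: 200 nM
Compound 2 `Clc1cccc(-n2ncnc2NCc2cccnc2)c1Cl`: 1320 nM

In a functional assay for antagonist activity at P2X purinoceptor 7 (Rattus norvegicus), read by FLIPR and calcium flux (a higher number here means a weaker inhibitor, a lower number a stronger inhibitor), compound 2 gives 1320 nM, the highest of the two numbers; compound 1 gives 200 nM, and the step of a 6.6-fold higher number from compound 1 to compound 2 (0.82 log units; beyond the scatter) separates them. Compound 3 `Cc1ncccc1CNc1ncnn1-c1cccc(Cl)c1Cl` differs from compound 2 by methyl in place of hydrogen on an aromatic carbon. Going by the values given here, no measured step isolates this change; the only one that bears on it, a 6.6-fold higher number from compound 1 to compound 2 (0.82 log units; beyond the scatter), combines a methyl loss with the ring change and ran toward weaker inhibition, so part of that step may reverse. Compound 3 is therefore expected to show a 2.6-fold lower number from compound 2 to compound 3 (0.42 log units; beyond the scatter), a modest move toward a lower number. The estimate for compound 3 is 500 nM, within 200 nM to 1500 nM.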

Compound 3, half-maximal inhibitory concentration: 295 nM
Estimate against measurement, compound 3: 1.7-fold (0.23 log units) above; low and high end bracket the measured number.
By their numbers in this assay, from the lowest: compounds 1 and 3 (each within the scatter of the next); then compound 2.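

In this assay, methyl in place of hydrogen on the aromatic carbon next to the ring nitrogen gives a step on its own (a 4.5-fold lower number from compound 2 to compound 3 (0.65 log units; beyond the scatter)), which the earlier pair could not separate from the ring change. With that methyl present, 2-methylpyridin-3-yl in place of 2-methylphenyl stays within the scatter (a 1.5-fold higher number from compound 1 to compound 3 (0.17 log units; within the scatter)), so the ring nitrogen shows no readable cost here. No measurement at hand explains either step. The compounds shown leave open whether ethyl, methoxy or chlorine on this carbon would serve as methyl does.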